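The source may report more compounds than this note shows. Statements on the series, on what has been measured and on what is new or still open speak of the compounds shown alone.

Measured so far in a functional assay on L5178Y cells (Mus musculus) for inhibition, read by MTT assay, with a stated time of 24 h; a higher number here means a weaker inhibitor, a lower number a stronger inhibitor:
- compound 1 `COc1cc(O)c2c(c1)O[C@H](c1ccc(O)cc1)C/C2=N\NC(=O)c1ccc(N)cc1`: >= 11300 nM
- compound 2 `COc1cc(O)c2c(c1)O[C@H](c1ccc(O)cc1)C/C2=N\NC(=O)c1ccco1`: >= 11300 nM
- compound 3 `COc1cc(O)c2c(c1)O[C@H](c1ccc(O)cc1)C/C2=N\NC(=O)Cc1c[nH]c2ccccc12`: >= 11300 nM

Each of these entries is a limit of the assay and not a number. Compound 1 stands at the limit of >= 11300 nM in this assay, at which 3 of the 3 values shown sit.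

Compound 4 `COc1ccc([C@@H]2C/C(=N\NC(=O)c3ccc(N)cc3)c3c(O)cc(OC)cc3O2)cc1` differs from compound 1 in one place: methyl in place of hydrogen on an oxygen on an aromatic ring. This changes 4-hydroxyphenyl to 4-methoxyphenyl.

Among the compounds with values here, no measured step makes this change. All three alter the group on the carbonyl carbon instead: a step that the two limits leave unreadable from compound 1 to compound 2, a step that the two limits leave unreadable from compound 1 to compound 3 and a step that the two limits leave unreadable from compound 2 to compound 3. Within the data shown here, they give no size to carry over, and they show only that three different groups on the shared core all ended at the same limit. The starting point is no firmer, as compound 1 has only the limit >= 11300 nM.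

In this assay, no change beyond the usual scatter can be predicted, so the expected result is a step that the limit leaves unreadable from compound 1 to compound 4, and compound 4 may well be reported as a limit too.

Compound 4 is estimated at 14000 nM, with an expected range from 6000 nM to 30000 nM.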

Compound 4, half-maximal inhibitory concentration: 3900 nM
Compound 4: middle estimate off by 3.6-fold (0.56 log units), on the high side; the whole stated range lies above it.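

In this assay, within the data shown here, methyl in place of hydrogen on an oxygen on an aromatic ring gives an at least 2.8-fold lower number from compound 1 to compound 4 (0.46 log units; beyond the scatter), the first step that can be read. The earlier steps shown here all changed the group on the carbonyl carbon, cannot be read, and said nothing about the 4-hydroxyphenyl group, whereas this change to 4-methoxyphenyl shows that the number responds to a change there. Compound 4 is the only compound shown that gives a measured number, while the others remain at a shared assay limit: the limit of >= 11300 nM in this assay, at which 3 of the 4 values shown sit.

Still open, as far as these compounds go, is whether a longer chain on that oxygen, such as ethyl, or an amine in place of the hydroxy would lower the number further. Also open, from the compounds shown here alone, is whether the same methyl would lower the number with the furan-2-yl group of compound 2 or the (1H-indol-3-yl)methyl group of compound 3.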